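From 4-isopropylpiperazin-1-yl to 4-(dimethylamino)piperidin-1-yl on the shared core

This account rests on a few compounds, and the source may have more. Where it says the series, first, only, none or still open, it means among the compounds named here.

Measured so far in an in vivo ADME assay on the whole organism for pharmacokinetics, with Rattus norvegicus as the target, at a dose of 3 mg/kg by the oral route; on this read-out higher numbers stand for higher oral bioavailability and lower numbers for lower oral bioavailability:
compound 1 `CN1CCN(c2cccc3nc(CN(CC4CC4)[C@H]4CCCc5cccnc54)cn23)CC1` with 31%
compound 2 `CC(C)N1CCN(c2cccc3nc(CN(C)[C@H]4CCCc5cccnc54)cn23)CC1` with 29%

Compound 2 at 29% stands within the usual scatter of compound 1 at 31%, so the numbers do not separate the two. Among the measured compounds shown here, these compounds differ in more than one place, and they offer no single-change step to lean on.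

Compound 3 `CN(C)C1CCN(c2cccc3nc(CN(C)[C@H]4CCCc5cccnc54)cn23)CC1` has not yet been measured. It keeps the core of compound 2, and the change is 4-(dimethylamino)piperidin-1-yl in place of 4-isopropylpiperazin-1-yl on an aromatic carbon, with the same atoms joined differently. For the measured compounds named here, no measured pair shows what this replacement does, so the expectation starts from compound 2 at 29% and assumes no step beyond the scatter in either direction. The expected step is a number 2 percentage points lower from compound 2 to compound 3 (within the scatter) and is estimated to remain within that scatter. In this assay the estimated value for compound 3 is 27%, with a range from 14% to 42% expected to hold most repeat measurements.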

Compound 3, oral bioavailability: 7%
Beside the measured number, compound 3's estimate is 20 percentage points above it; the measured number lies below the stated range.
By their numbers in this assay, from the lowest: compound 3; then compounds 2 and 1 (each within the scatter of the next).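

In this assay the position on the aromatic carbon next to the ring nitrogen proves sensitive to this change, which gives a number 22 percentage points lower from compound 2 to compound 3 (beyond the scatter). Among the compounds shown here, this is the first single-change step, and it shows that keeping the same atoms does not keep the read-out: the two groups differ in how those atoms are joined, with a six-membered non-aromatic ring holding 2 hetero atoms in 4-isopropylpiperazin-1-yl and 1 hetero atom in 4-(dimethylamino)piperidin-1-yl. No measurement is available that would tie the step to any property of either group.

On these data alone, compound 1 differs from compound 2 in more than one place, so the step rests on this single pair, and whether 4-(dimethylamino)piperidin-1-yl would have a similar effect on the core of compound 1 remains open. Also open, as far as these compounds go, is whether a morpholin-4-yl group or a 4-aminopiperidin-1-yl group in this place would stay near compound 2 or fall near compound 3.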